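Extending the aryl ether of compound 2

This account rests on a few compounds, and the source may have more. Where it says the series, first, only, none or still open, it means among the compounds named here.

Compound 1 `CC(C)(C)c1cc(NC(=O)c2ccc(Cl)cc2Cl)ccc1O` carries a free hydroxyl on an aromatic ring. In an assay on isolated protein for antagonist activity at Bile acid receptor (Homo sapiens), read by HTRF, with a stated time of 30 min (on this read-out higher numbers stand for weaker inhibition and lower numbers for stronger inhibition), compound 1 gives 13600 nM. Compound 2 `COc1ccc(NC(=O)c2ccc(Cl)cc2Cl)cc1C(C)(C)C` is its methyl ether. In this assay compound 2 gives only a limit, > 100000 nM. On these data alone, the step of an at least 7.3-fold higher number from compound 1 to compound 2 (0.86 log units; beyond the scatter) thus runs toward weaker inhibition, and compound 2 sits at the limit described by the limit of > 100000 nM in this assay, at which 1 of the 2 values shown sits, so its true number is unknown.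

Compound 3 `C=CCOc1ccc(NC(=O)c2ccc(Cl)cc2Cl)cc1C(C)(C)C` lengthens the ether: vinyl in place of hydrogen on a saturated chain carbon bound to an oxygen on an aromatic ring. Among the compounds with values here, the only measured step at this position is an at least 7.3-fold higher number from compound 1 to compound 2 (0.86 log units; beyond the scatter), which concerns the hydroxyl hydrogen rather than growth of the ether, so no measured step bears directly on this change. With compound 2 already at the limit, compound 3 is expected to stay at about the same level, and a step that the limit leaves unreadable from compound 2 to compound 3 is estimated as small. Compound 3 is expected to give 150000 nM, within 50000 nM to 500000 nM, most likely again reported only as a limit.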

Compound 3, half-maximal inhibitory concentration: > 100000 nM
Compound 3: a limit, no number; the forecaster's own chance of this, stated with the estimate: 75%; the middle value does not contradict the limit.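

In this assay compound 3 gives only a limit, > 100000 nM. Replacing the hydroxyl hydrogen of compound 1 with allyl gives an at least 7.3-fold higher number from compound 1 to compound 3 (0.86 log units; beyond the scatter), so the weaker inhibition seen with the methyl ether also holds for this second ether, and both ethers shown, compound 2 and compound 3, go the same way with no exception among them. The change from methoxy to allyloxy cannot be read, because both values are limits: the limit of > 100000 nM in this assay, at which 2 of the 3 values shown sit.

Still open, on these data alone, is whether an ether chain ending in a carboxylic acid or an amine would give a readable number in this assay. Also open, as far as these compounds go, is whether any replacement for the hydroxyl hydrogen of compound 1 keeps inhibition at the level of compound 1.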